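The source may report more compounds than this note shows. Statements on the series, on what has been measured and on what is new or still open speak of the compounds shown alone.

Compound 1 `O=C(Nc1cccc([N+](=O)[O-])c1)Nc1nc2ccc(Cl)cc2s1`: in a functional assay on NUGC-3 cells (Homo sapiens) for antiproliferative activity, read by sulforhodamine B assay (a higher number here means a weaker inhibitor of growth, a lower number a stronger inhibitor of growth), compound 1 gives 1.03 ug/mL.
Compound 2 `COc1ccc2sc(NC(=O)c3ccc(C)cc3)nc2c1`: in this assay compound 2 gives > 10 ug/mL, which is a limit of the assay and not a number.
Compound 3 `COc1ccc(C(=O)Nc2nc3cc(OC)ccc3s2)cc1`: in this assay compound 3 gives > 10 ug/mL, again a limit of the assay and not a number.

Compound 3 thus stands at the top edge of what this assay reports, together with compound 2. Among the measured compounds shown here, the one single-point step measured among the amides, a step that the two limits leave unreadable from compound 2 to compound 3, cannot be read because both ends sit at the limit of > 10 ug/mL in this assay, at which 2 of the 3 values shown sit. For the measured compounds named here, compound 1, on a different core, is the only compound with a numerical value.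

Compound 4 `COc1ccc2sc(NC(=O)c3ccc([N+](=O)[O-])cc3)nc2c1` differs from compound 3 by nitro in place of methoxy on an aromatic carbon. Going by the values given here, no measured step exchanges a nitro for a methoxy, and the only step within the amides is unreadable, so the numbers give neither a size nor a direction for this change in this assay. Compound 4 is expected to stay near the limit, estimated at 12 ug/mL with a range of 3 ug/mL to 40 ug/mL. The step that the limit leaves unreadable from compound 3 to compound 4 is accordingly expected to remain unreadable, more likely than not ending in a limit again.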

Compound 4, concentration for 50% growth inhibition: > 10 ug/mL
Compound 4: a limit, no number; the forecaster's own chance of this, stated with the estimate: 60%; the middle value is on the limit's open side.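

Among the compounds shown here, compound 2, compound 3 and compound 4 all sit at a limit of this assay, not at a number, so no step among them can be read: the limit of > 10 ug/mL in this assay, at which 3 of the 4 values shown sit. The compounds shown leave open whether methyl, methoxy or nitro on that aromatic carbon differ at all.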